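The compounds below may be only part of what the source reports. "The series", "measured", "known", "first", "only" and "open" are said of these compounds alone.

Compound 1, `Nc1nc(N)c2cc(CSC(=S)N3CCN(c4ccccc4)CC3)ccc2n1`, is the starting point. In a functional assay on HT-29 cells (Homo sapiens) for antiproliferative activity, read by MTT assay, with a stated time of 72 h (a lower number here means a stronger inhibitor, a higher number a weaker inhibitor), compound 1 gives 2760 nM, the lowest of the three numbers measured here, although its steps to the other two compounds both fall within the scatter. Compound 2, `Cc1ccc(N2CCN(C(=S)SCc3ccc4nc(N)nc(N)c4c3)CC2)c(C)c1`, gives 2970 nM in this assay, and compound 3, `Nc1nc(N)c2cc(CSC(=S)N3CCN(c4ccccc4Cl)CC3)ccc2n1`, gives 3900 nM. The steps among them are small: a 1.1-fold higher number from compound 1 to compound 2 (0.03 log units; within the scatter), a 1.4-fold higher number from compound 1 to compound 3 (0.15 log units; within the scatter) and a 1.3-fold higher number from compound 2 to compound 3 (0.12 log units; within the scatter).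

Compound 4, `Nc1nc(N)c2cc(CSC(=S)N3CCN(c4ncccn4)CC3)ccc2n1`, has not yet been measured. It differs from compound 1 in one place: pyrimidin-2-yl in place of phenyl on an amine nitrogen in a ring. The group sits on an amine nitrogen in a ring of a six-membered non-aromatic ring with 2 nitrogen. The three measured steps all alter the same position, exchanging phenyl for 2,4-dimethylphenyl or 2-chlorophenyl, and none of them moved this assay beyond the scatter. Among the measured compounds shown here, no measured step replaces ring carbon with nitrogen in the aromatic ring on that amine nitrogen, so the effect of pyrimidin-2-yl is untested here.

Given that every change at this position so far left the number essentially unchanged, compound 4 is expected to stay close to compound 1, with a 1.3-fold higher number from compound 1 to compound 4 (0.10 log units; within the scatter) as the estimated step. The estimate for compound 4 in this assay is 3500 nM, within a range from 1500 nM to 8000 nM.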

Compound 4, half-maximal inhibitory concentration: 4720 nM
For compound 4 the middle estimate is 1.3-fold (0.13 log units) below the measured one; low and high end bracket the measured number.
By their numbers in this assay, from the lowest: compounds 1, 2, 3 and 4 (each within the scatter of the next).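

In this assay, among the compounds shown here, pyrimidin-2-yl is the first group at this position whose aromatic ring holds hetero atoms rather than carbon only, and the swap gives a 1.7-fold higher number from compound 1 to compound 4 (0.23 log units; within the scatter); read against the two substituted phenyl groups, it gives a 1.6-fold higher number from compound 2 to compound 4 (0.20 log units; within the scatter) and a 1.2-fold higher number from compound 3 to compound 4 (0.08 log units; within the scatter). The tolerance seen among the phenyl-type groups on this amine nitrogen therefore extends to a ring with ring nitrogen and hydrogen-bond acceptors, as all three steps stay within the scatter and the four compounds cannot be separated by this read-out. No measurement is available that would explain this flat result or link it to any property of the groups.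

All four compounds carry a six-membered aromatic ring on this amine nitrogen, so the compounds shown leave open how the number responds to a saturated ring such as cyclohexyl, a benzyl group, or a five-membered aromatic ring such as thiazol-2-yl. They also leave open whether any change here can move the number beyond the scatter, or whether a change elsewhere on the shared core would be needed.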